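Prenyl on the fused ring of the unsubstituted core

The compounds below may be only part of what the source reports. "The series", "measured", "known", "first", "only" and "open" are said of these compounds alone.

Compound 3 `C=CC(C)(C)c1[nH]c2ccccc2c1/C=c1\[nH]c(=O)c(=C)[nH]c1=O` stands at the limit of an ADME assay on MDCK cells (Canis lupus familiaris) for cytotoxicity, read by CellTiter-Glo, with a stated time of 40 h; on this read-out lower numbers stand for higher toxicity in this test and higher numbers for lower toxicity in this test: in this assay compound 3 gives > 200000 nM, a limit and not a number. Compound 1 `C=CC(C)(C)c1[nH]c2ccc(C[C@H](O)C(C)(C)O)cc2c1/C=c1\[nH]c(=O)c(=C)[nH]c1=O` gives in this assay > 200000 nM, also a limit. Compound 2 `C=CC(C)(C)c1[nH]c2ccc(C[C@H](O)C(C)(C)OC)cc2c1/C=c1\[nH]c(=O)c(=C)[nH]c1=O` gives in this assay > 200000 nM, again a limit. The steps a step that the two limits leave unreadable from compound 1 to compound 2, a step that the two limits leave unreadable from compound 1 to compound 3 and a step that the two limits leave unreadable from compound 2 to compound 3 are therefore unreadable in size, because of the limit of > 200000 nM in this assay, at which 3 of the 3 values shown sit. Compound 4 `C=CC(C)(C)c1[nH]c2c(CC=C(C)C)cccc2c1/C=c1\[nH]c(=O)c(=C)[nH]c1=O` differs from compound 3 by 3-methylbut-2-en-1-yl in place of hydrogen on an aromatic carbon. Among the measured compounds shown here, no measured step reads out a size, so nothing beyond the scatter is expected for this assay. For compound 4 an expected value of 200000 nM is estimated, between 80000 nM and 400000 nM. The expected step of a number no higher from compound 3 to compound 4 (the limit leaves the size open) is thus essentially none, most likely again reported only as a limit.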

Compound 4, half-maximal cytotoxic concentration: > 200000 nM
Compound 4 ended at the assay's limit; the forecaster's own chance of this, stated with the estimate: 75%; the middle value lies on the limit itself.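

In this assay the step between compound 3 and compound 4 cannot be read in size, because both sit at a limit: the limit of > 200000 nM in this assay, at which 4 of the 4 values shown sit.

The compounds shown leave open whether any change on the shared core alters cytotoxicity, since none gives a number.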